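Hydroxy in place of hydrogen on compound 2

The compounds below may be only part of what the source reports. "The series", "measured", "known", "first", "only" and "open" are said of these compounds alone.

For the measured compounds named here, in a functional assay on cells (Endothelial cell) for inhibition (on this read-out higher numbers stand for weaker inhibition and lower numbers for stronger inhibition), compound 2 (`CC(C)(C)c1cc(-c2cc(=O)c3ccccc3o2)cc(C(C)(C)C)c1O`) gives 2500 nM, the higher of the two numbers so far, while compound 1 (`CC(C)(C)c1cc(-c2cc(=O)c3ccc(OCC(=O)O)cc3o2)cc(C(C)(C)C)c1O`) gives 500 nM. Compound 3 (`CC(C)(C)c1cc(-c2cc(=O)c3ccc(O)cc3o2)cc(C(C)(C)C)c1O`) has hydroxy in place of hydrogen on an aromatic carbon of compound 2: hydroxy in place of hydrogen on an aromatic carbon. Going by the values given here, the one measured step that bears on this is a 5.0-fold higher number from compound 1 to compound 2 (0.70 log units; beyond the scatter), where hydrogen replaces carboxymethoxy. Read in reverse, it points towards a lower number, and only part of it is expected to return with hydroxy. The expected move is a 2.5-fold lower number from compound 2 to compound 3 (0.40 log units; beyond the scatter). For compound 3 the estimate is 1000 nM, with an expected range of 350 nM to 2800 nM.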

Compound 3, half-maximal inhibitory concentration: 2000 nM
Compound 3: the middle estimate sits 2.0-fold (0.30 log units) below what was measured; measured number inside the range.
By their numbers in this assay, from the lowest: compound 1; then compounds 3 and 2 (each within the scatter of the next).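

Hydroxy in place of hydrogen on this aromatic carbon does not separate compound 3 from compound 2 in this assay (a 1.3-fold lower number from compound 2 to compound 3 (0.10 log units; within the scatter)). The oxygen alone therefore does not account for the lower number of compound 1, and the carboxymethyl on that oxygen does make a difference (a 4.0-fold higher number from compound 1 to compound 3 (0.60 log units; beyond the scatter)). No available evidence explains this. The compounds shown leave open whether the carboxylic acid itself is needed, or whether a methyl ester, a primary amide or a plain methoxy would match carboxymethoxy here. They also leave open how a longer chain ending in the acid would read.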